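The source may hold more compounds than are shown below. What is called first, only, known or untested is meant among the compounds shown, and "the series" means these compounds.

Among the measured compounds shown here, compound 3 `COc1ccc(-c2nc(C(=O)N(C)C)sc2-c2ccc(OC)cc2)cc1` gives 3 uM in a functional assay (aorta) with Rattus norvegicus as the target (a higher number here means that more compound is needed for the effect, a lower number that less compound is needed), the lowest of the three numbers measured so far. Its nearest neighbour is compound 1 `COc1ccc(-c2nc(/N=C(\N)N(C)C)sc2-c2ccc(OC)cc2)cc1`, which gives 4.8 uM in this assay, and a 1.6-fold lower number from compound 1 to compound 3 (0.20 log units; within the scatter). Compound 2 `COc1ccc(-c2nc(/N=C(\N)[N+]3(C)CCCCC3)sc2-c2ccc(OC)cc2)cc1` gives 21 uM in this assay; here a 7.0-fold lower number from compound 2 to compound 3 (0.85 log units; beyond the scatter), and a 4.4-fold higher number from compound 1 to compound 2 (0.64 log units; beyond the scatter). The unmeasured compound 4 `COc1ccc(-c2nc(CCC(=O)O)sc2-c2ccc(OC)cc2)cc1` differs from compound 3 in one place: 2-carboxyethyl in place of dimethylcarbamoyl on an aromatic carbon. For the measured compounds named here, no measured step exchanges any group for a 2-carboxyethyl group, so only indirect guidance exists. Going by the values given here, the two measured steps into compound 3 show that exchanges at this aromatic carbon have moved the number by modest amounts at most, from within the scatter up to a modest change, and none of the measured groups carries a hydrogen-bond donor as the 2-carboxyethyl group does. The new group therefore lies outside what the measured compounds cover, and the expected step is given a wide range; compound 4 is expected to need somewhat more compound than compound 3, with a 2.7-fold higher number from compound 3 to compound 4 (0.43 log units; beyond the scatter). The estimate for compound 4 in this assay is 8 uM, with a range from 2 uM to 40 uM.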

Compound 4, concentration for half-maximal effect: > 100 uM
Compound 4 ended at the assay's limit (the forecaster's own chance of this, stated with the estimate: 15%); middle value at least 12-fold (1.09 log units) away from the limit.
By their numbers in this assay, from the lowest: compounds 3 and 1 (each within the scatter of the next); then compound 2. At a limit, above all of these: compound 4.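

At the aromatic carbon next to the ring nitrogen and next to the ring sulfur, not every exchange is tolerated: in this assay compound 4 stands only at a limit of the assay, > 100 uM. Replacing dimethylcarbamoyl with 2-carboxyethyl gives an at least 33-fold higher number from compound 3 to compound 4 (1.52 log units; beyond the scatter), and the other two comparisons give an at least 20-fold higher number from compound 1 to compound 4 (1.31 log units; beyond the scatter) and an at least 4.7-fold higher number from compound 2 to compound 4 (0.67 log units; beyond the scatter), the last being the smallest. Among the compounds shown here, the earlier exchanges at this carbon, a 1.6-fold lower number from compound 1 to compound 3 (0.20 log units; within the scatter) and a 7.0-fold lower number from compound 2 to compound 3 (0.85 log units; beyond the scatter), stayed within the scatter or were modest, so this position shows its first large steps here, and the one from compound 3 arises between two groups with the same number of heavy atoms, so that this count alone does not account for the change.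

The compounds shown leave open how far compound 4 really lies past its limit, since only the limit is available. They also leave open whether the loss follows the carboxylic acid itself or the chain that carries it, which the methyl ester of the same chain, or a carboxylic acid set directly on the aromatic carbon, would help to separate.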